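Polar side-chain variation on the shared core

The compounds below may be only part of what the source reports. "The series", "measured", "known", "first", "only" and "open" are said of these compounds alone.

Measured so far:
compound 1, `CCCCCCCCCCc1ccc(-c2noc(CCCN(C)C)n2)cc1`: 8%
compound 2, `CCCCCCCCCCc1ccc(-c2noc(CC3CCNC3)n2)cc1`: 44%
compound 3, `CCCCCCCCCCc1ccc(-c2noc(CC(CN)OC(C)=O)n2)cc1`: 0%

In an assay on HeLa cells for inhibition of sphingosine-1-phosphate transporter SPNS2 (Mus musculus), read by LC-MS, tested at 2 uM (a higher number here means more inhibition at the concentration tested (going by the name of the read-out), a lower number less inhibition), compound 3 gives 0%, the lowest of the three numbers. Its nearest neighbour is compound 1: the step of a number 8 percentage points lower from compound 1 to compound 3 (within the scatter). The furthest is compound 2: the step of a number 44 percentage points lower from compound 2 to compound 3 (beyond the scatter). Going by the values given here, the only large movement in the set is a number 36 percentage points higher from compound 1 to compound 2 (beyond the scatter), the one step in which the five-membered ring enters.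

Compound 4, `CCCCCCCCCCc1ccc(-c2noc([C@H](CCCCN)NC(C)=O)n2)cc1`, is the next member. Relative to compound 3 the change is a group of 10 heavy atoms (7 carbon, 2 nitrogen, 1 oxygen; no ring) in place of a group of 8 heavy atoms (5 carbon, 1 nitrogen, 2 oxygen; no ring), on an aromatic carbon. The step bears on the two measured steps that also rework this same chain, from compound 1 to compound 3 and from compound 2 to compound 3, since compound 4 again carries no ring, and both an acetamido and a primary amine remain present. Among the compounds with values here, the step from compound 1 to compound 3 was within the scatter; the only large step required a ring. The expected step in this assay is therefore small, with no clear direction beyond the scatter. Compound 4 is expected to give 10%, within 0% to 30%. This estimate means a step of a number 10 percentage points higher from compound 3 to compound 4 (within the scatter), expected to lie within the scatter.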

Compound 4, a percentage reported as inhibition, at one concentration (the size of the read-out at that concentration, not a potency): 40%
Compound 4: the middle estimate sits 30 percentage points below what was measured, outside the stated range (above it).
By their numbers in this assay, from the lowest: compounds 3 and 1 (each within the scatter of the next); then compounds 4 and 2 (each within the scatter of the next).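

In this assay, the 1-acetamido-5-aminopentyl group gives a number 40 percentage points higher from compound 3 to compound 4 (beyond the scatter) and a number 32 percentage points higher from compound 1 to compound 4 (beyond the scatter), so a large rise on this aromatic carbon does not depend on a ring in the side chain, although compounds 1 and 3, also without a ring, stay low. The comparison with the ring-bearing side chain gives a number 4 percentage points lower from compound 2 to compound 4 (within the scatter), placing the open-chain and pyrrolidine-containing groups on the same footing in this assay. No supporting data bear on what lies behind these steps.

From the compounds shown here alone, it remains open whether a carboxylic acid in place of the terminal amine of 1-acetamido-5-aminopentyl would keep this inhibition. The compounds shown also do not separate the contributions of the acetamido group, the terminal amine and the defined stereocentre.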